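Replacing the 3-methyl-1,2-oxazol-5-yl group of compound 1

This account rests on a few compounds, and the source may have more. Where it says the series, first, only, none or still open, it means among the compounds named here.

Compound 1 `COc1ccc(/C=C/c2cc(C)no2)cc1OC`: > 100000 nM
Compound 2 `COc1ccc(/C=C/c2cc(C)no2)cc1`: > 100000 nM

Both entries come from a functional assay on MCF7 cells (Homo sapiens) for cytotoxicity, read by MTT assay, with a stated time of 72 h (on this read-out higher numbers stand for weaker inhibition and lower numbers for stronger inhibition), and neither is a number. Compound 1 stands only at a limit, which compound 2 shares: the limit of > 100000 nM in this assay, at which 2 of the 2 values shown sit. Going by the values given here, the one measured step, a step that the two limits leave unreadable from compound 1 to compound 2, puts hydrogen in place of methoxy on an aromatic carbon. It leaves the group changed here untouched and gives no size to carry over. Compound 3 `COc1ccc(/C=C/c2cc(C)n[nH]2)cc1OC` differs from compound 1 as follows: 3-methyl-1H-pyrazol-5-yl in place of 3-methyl-1,2-oxazol-5-yl on a double-bonded chain carbon bound to a double-bonded chain carbon. Among the compounds with values here, no measured step bears on this exchange. Compound 1 offers only its limit as a starting point, > 100000 nM. A small move toward stronger inhibition in this assay is expected, though with low confidence, and the estimated step is an at least 1.4-fold lower number from compound 1 to compound 3 (0.15 log units; that floor lies within the scatter). For compound 3 the estimated value is 70000 nM, with an expected range from 20000 nM to 200000 nM.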

Compound 3, half-maximal inhibitory concentration: 12600 nM
Compound 3: middle estimate off by 5.6-fold (0.74 log units), on the high side, outside the stated range (below it).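

In this assay, 3-methyl-1H-pyrazol-5-yl in place of 3-methyl-1,2-oxazol-5-yl on a double-bonded chain carbon bound to a double-bonded chain carbon gives an at least 7.9-fold lower number from compound 1 to compound 3 (0.89 log units; beyond the scatter), so this position can respond to a change of group, whereas the step from compound 1 to compound 2 cannot be read. The size of that step is only a floor, and compound 3 is the one compound shown with a number rather than a limit: the limit of > 100000 nM in this assay, at which 2 of the 3 values shown sit.

The entering group has a hydrogen-bond donor and the leaving group has none, but the compounds shown do not tell whether that difference accounts for the step. Also open, as far as these compounds go, is whether a methyl group on the ring nitrogen would keep the step, and whether an amine in place of the ring methyl would change it.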